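A few compounds are considered here, and "the series" means these few. Any claim that something is new, unique, unknown or untested is made for them only; others in the source may bear on it.

Working notes on the series. Compound 1 `CN1C[C@H]2C=C(c3cccnc3)C[C@H](C2)C1` gives 2.1 nM in an in vitro assay on SH-EP1 cells for displacement of a labelled ligand from Neuronal acetylcholine receptor; alpha4/beta2 (Homo sapiens) (on this read-out higher numbers stand for weaker inhibition and lower numbers for stronger inhibition), the highest of the three numbers recorded. Compound 3 `C1=C(c2cnccn2)CC2CNCC1C2` gives 1.1 nM, a gap that lies within the scatter, so no order between compound 1 and compound 3 is claimed. Compound 2 `C1=C(c2cncnc2)CC2CNCC1C2` gives 0.2 nM, clearly lower than compound 1 and beyond the scatter.

Compound 4 `CN1C[C@@H]2C=C(c3cccnc3)C[C@@H](C2)C1` differs from compound 1 as follows: the two compounds have the same atoms and bonds and differ only in configuration as drawn: 2 of 2 stereo elements differ (all stereocentres are inverted: mirror images); a stereocentre at a saturated ring carbon is drawn R in compound 1 and S in compound 4; a stereocentre at a saturated ring carbon is drawn S in compound 1 and R in compound 4. Among the compounds with values here, no step between two measured mirror images is recorded, so the size and direction of this change are unknown. A modest loss is expected, as a 2.9-fold higher number from compound 1 to compound 4 (0.46 log units; beyond the scatter), with a wide range. Compound 4 is estimated at 6 nM, between 1 nM and 40 nM.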

Compound 4, inhibition constant: 9.4 nM
Estimate against measurement, compound 4: 1.6-fold (0.19 log units) below, and the stated range covers the measured number.
By their numbers in this assay, from the lowest: compound 2; then compounds 3 and 1 (each within the scatter of the next); then compound 4.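

In this assay, within the data shown here, inverting both stereocentres gives a 4.5-fold higher number from compound 1 to compound 4 (0.65 log units; beyond the scatter), the first measured step between mirror images. Configuration alone therefore moves the number beyond the scatter, and compound 1 is the form with the lower number of this pair. The step can be ascribed to configuration and to nothing else: the fact that compounds 1 and 4 differ only in the configuration as drawn.

On these data alone, compounds 2 and 3 carry no drawn configuration, so whether the same order of mirror images holds for them stays open. Also open, as far as these compounds go, is whether an ethyl group in place of the methyl group keeps this gap.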